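Working notes: from compound 3 to compound 4

A few compounds are considered here, and "the series" means these few. Any claim that something is new, unique, unknown or untested is made for them only; others in the source may bear on it.

- Compound 1 `Cc1c(-c2ccc(Cc3ccc(OCC(F)(F)F)cc3)cc2)[nH]c2cccc(F)c2c1=O` gives > 5000 nM as a limit
- Compound 2 `Cc1c(-c2ccc(Cc3ccc(C(C)(O)C(F)(F)F)cc3)cc2)[nH]c2cccc(F)c2c1=O` gives > 2500 nM as a limit
- Compound 3 `Cc1c(-c2ccc(Cc3ccc(S(=O)(=O)C(F)(F)F)cc3)cc2)[nH]c2cccc(F)c2c1=O` gives > 2500 nM as a limit

In an ADME assay on Huh7.5.1 cells (Homo sapiens) for cytotoxicity, read by WST assay, with a stated time of 48 h (a lower number here means that less compound is tolerated, a higher number that more compound is tolerated), compound 3 holds a limit and not a number, and that is the limit of > 2500 nM in this assay, at which 2 of the 3 values shown sit, so it has no readable rank. Compound 1 differs in holding the limit of > 5000 nM in this assay, at which 1 of the 3 values shown sits, as its limit. Compound 4 `Cc1c(-c2ccc(Cc3ccc(Cl)cc3)cc2)[nH]c2cccc(F)c2c1=O` is not yet measured, and the change is chloro in place of (trifluoromethyl)sulfonyl on an aromatic carbon in which chloro replaces (trifluoromethyl)sulfonyl on an aromatic carbon. Three measured steps at this place bear on it: a step that the two limits leave unreadable from compound 1 to compound 2 and a step that the two limits leave unreadable from compound 1 to compound 3 and a step that the two limits leave unreadable from compound 2 to compound 3 with no size or direction among them. No step beyond the scatter is therefore expected in this assay on this thin basis. The expected change is a step that the limit leaves unreadable from compound 3 to compound 4 as an estimate only. For compound 4 the estimate is 5000 nM with an expected range of 2000 nM to 20000 nM and a further limit is likely.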

Compound 4, half-maximal cytotoxic concentration: > 10000 nM
Compound 4 ended at the assay's limit; the forecaster's own chance of this, stated with the estimate: 75%; at least 2.0-fold (0.30 log units) between middle value and limit.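

Compound 4 gives > 10000 nM, a limit and not a number, so its steps from compound 1, compound 2 and compound 3 cannot be read. The compounds shown leave open whether the group at this place changes tolerance at all.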